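Notes on a weakly active amide series

This account rests on a few compounds, and the source may have more. Where it says the series, first, only, none or still open, it means among the compounds named here.

Compound 1 `Cc1nc(-c2ccccc2)c(C(=O)N2CCN(c3ccc(C(F)(F)F)cc3)CC2)o1` is tested in a functional assay on HL-60 cells (Homo sapiens) for inhibition, read by MTT assay, with a stated time of 72 h; on this read-out higher numbers stand for weaker inhibition and lower numbers for stronger inhibition. For compound 1 the reported result is a limit of the assay, > 1000 nM; it sits at the limit of > 1000 nM in this assay, at which 1 of the 3 values shown sits, and no single number is given for it. The two other measured members of the series carry no number either. Compound 2 `COc1cccc(N2CCN(C(=O)c3oc(C(F)(F)F)nc3-c3ccc(F)cc3)CC2)c1` is recorded in this assay as "not active" (no number reported). Compound 3 `Cc1nc(-c2ccccc2)c(C(=O)N2CCN(c3ccc(C(=O)C(C)C)cc3)CC2)o1` is recorded in this assay as "not active" (no number reported). Across the three measured compounds there is thus no step between two numbers, only one limit and two entries without a value, and nothing in the series so far shows inhibition that can be expressed as a number.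

Compound 4 `CCOc1cccc(N2CCN(C(=O)c3oc(C)nc3-c3ccccc3)CC2)c1` has not been measured. It differs from compound 1 in one place: 3-ethoxyphenyl in place of 4-(trifluoromethyl)phenyl on an amine nitrogen in a ring. Among the measured compounds shown here, no measured pair shows what this change does to the read-out. The expected step that the limit leaves unreadable from compound 1 to compound 4 is therefore none beyond the scatter, and a second limit rather than a number is the more likely outcome. Compound 4 is estimated at 3000 nM, in a range from 700 nM to 20000 nM.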

Compound 4, half-maximal inhibitory concentration: 151 nM
The estimate for compound 4 lay 20-fold (1.30 log units) above the measured number, and the stated range ends above it.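

Notes on position: the substituent on the amine nitrogen in the ring is where the read-out moves. In this assay, 3-ethoxyphenyl in place of 4-(trifluoromethyl)phenyl on the shared core gives an at least 6.6-fold lower number from compound 1 to compound 4 (0.82 log units; beyond the scatter), the only change shown here that leads to inhibition expressed as a number. The size of this step is only a minimum, and the entry for compound 1 is a limit and not a number: the limit of > 1000 nM in this assay, at which 1 of the 4 values shown sits. Compound 3, which differs from compound 4 only in the substituted phenyl on this nitrogen, is recorded as not active, so a number is not reached with every phenyl group at this place.

This single pair does not separate the effect of adding the ethoxy group from that of removing the trifluoromethyl group, nor does it show how much depends on where the ethoxy group stands on the phenyl ring. How a propoxy chain, a hydroxyl group or an amine would read in place of the ethoxy group remains open, and the compounds shown give no cause for the step.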